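This account rests on a few compounds, and the source may have more. Where it says the series, first, only, none or still open, it means among the compounds named here.

In an assay on CHO cells, read by calcium flux (on this read-out higher numbers stand for weaker inhibition and lower numbers for stronger inhibition), compound 1 `O=C(Nc1ccccc1)c1csc(Cc2c(Cl)cccc2Cl)n1` gives only a limit of the assay, > 4000 nM. Compound 2 `O=C(Nc1ccc(Br)cc1)c1csc(Cc2c(Cl)cccc2Cl)n1` gives 460 nM, and compound 3 `N#Cc1ccc(NC(=O)c2csc(Cc3c(Cl)cccc3Cl)n2)cc1` gives 720 nM, the higher of the two numbers, although a 1.6-fold higher number from compound 2 to compound 3 (0.19 log units; within the scatter). The change to compound 4 `O=C(Nc1cccc(Br)c1)c1csc(Cc2c(Cl)cccc2Cl)n1` is 3-bromophenyl in place of 4-cyanophenyl on an amide-type nitrogen. For the measured compounds named here, three measured steps bear on it: an at least 8.6-fold lower number from compound 1 to compound 2 (0.93 log units; beyond the scatter), an at least 5.5-fold lower number from compound 1 to compound 3 (0.74 log units; beyond the scatter) and a 1.6-fold higher number from compound 2 to compound 3 (0.19 log units; within the scatter). A bromo and a cyano on the aromatic carbon each lower the number by a comparable amount, and the two differ from each other only within the scatter, so the bromophenyl entering here is expected to leave compound 4 near compound 3, with a 1.0-fold higher number from compound 3 to compound 4 (0.02 log units; within the scatter) expected to stay within the scatter. Compound 4 is therefore estimated at 750 nM, between 250 nM and 2500 nM.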

Compound 4, half-maximal inhibitory concentration: > 4000 nM
Compound 4: no number, only a limit (the forecaster's own chance of this, stated with the estimate: 10%); at least 5.3-fold (0.72 log units) between middle value and limit.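

In this assay, the mere presence of a bromo on the phenyl group on the amide-type nitrogen is not enough: 3-bromophenyl in place of 4-bromophenyl gives an at least 8.6-fold higher number from compound 2 to compound 4 (0.93 log units; beyond the scatter), and 3-bromophenyl in place of 4-cyanophenyl gives an at least 5.5-fold higher number from compound 3 to compound 4 (0.74 log units; beyond the scatter). Among the compounds shown, a lower number goes with 4-bromophenyl and 4-cyanophenyl, not with 3-bromophenyl. The step between compound 1 and compound 4 cannot be read: the limit of > 4000 nM in this assay, at which 2 of the 4 values shown sit.

On these data alone, compound 4 gives only a limit, > 4000 nM, so how weak it is stays open. As far as these compounds go, whether an amine, a carboxylic acid or a methoxy group on this phenyl group would give a low number also stays open.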